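Swapping One Methyl for Hydrogen on Compound 2

This account rests on a few compounds, and the source may have more. Where it says the series, first, only, none or still open, it means among the compounds named here.

Measured in a functional assay on the whole organism (Hindlimb, strain albino) with Mus musculus as the target, in the maximal electroshock model, with a stated time of 0.5 h; on this read-out lower numbers stand for an effect already at smaller amounts and higher numbers for an effect only at larger amounts of compound:
Compound 1 `CC(=O)N1N=C(Nc2nc3ccccc3s2)CC1c1ccc(Cl)cc1`: 209 umol/kg
Compound 2 `CC(=O)N1N=C(Nc2nc3ccc(C)cc3s2)CC1OC1=CC=C1`: 160 umol/kg

Compound 2, at 160 umol/kg, lies within the usual scatter of compound 1, at 209 umol/kg, so these two numbers cannot be ranked. Compound 3 `CC(=O)N1N=C(Nc2nc3ccccc3s2)CC1OC1=CC=C1` has not yet been measured. It is compound 2 with a single structural change, hydrogen in place of methyl on an aromatic carbon. Going by the values given here, no pair of measured compounds differs in one place only, so the data do not show what this change does. With nothing pointing either way, no step beyond the scatter is expected in this assay, and the estimate stays close to compound 2 at 160 umol/kg. The expected change is a 1.1-fold higher number from compound 2 to compound 3 (0.03 log units; within the scatter). For compound 3 the expected value is 170 umol/kg, with an estimated range from 80 umol/kg to 350 umol/kg.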

Compound 3, dose for half-maximal effect: 382 umol/kg
Estimate against measurement, compound 3: 2.2-fold (0.35 log units) below, and the stated range ends below it.
By their numbers in this assay, from the lowest: compounds 2, 1 and 3 (each within the scatter of the next, the first and the last beyond it).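

Hydrogen in place of methyl on this aromatic carbon is the first single change here that can be read, giving a 2.4-fold higher number from compound 2 to compound 3 (0.38 log units; beyond the scatter) in this assay and showing that this position on the six-membered aromatic ring affects the dose needed, though only modestly. At the saturated ring carbon, exchanging the six-membered aromatic ring group that carries chlorine for the four-membered non-aromatic ring group gives a 1.8-fold higher number from compound 1 to compound 3 (0.26 log units; within the scatter) and so cannot be told apart from no change. No accompanying measurement accounts for the effect of the methyl.

An ethyl group, a methoxy group or a chlorine on the same aromatic carbon could show whether the step is specific to methyl. From the compounds shown here alone, it also remains open whether methyl would give a similar step on the core of compound 1.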